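A Carboxy Group in Place of Chloro: Expected Effect

The source may report more compounds than this note shows. Statements on the series, on what has been measured and on what is new or still open speak of the compounds shown alone.

Of the compounds shown here, three sharing one core have been measured in a functional assay (aorta) with Rattus norvegicus as the target; a higher number here means a weaker inhibitor, a lower number a stronger inhibitor. Compound 1 `CC1(C)Oc2ccc(C#N)cc2[C@@H](NC(=O)NCc2ccccc2)[C@@H]1O` gives 5600 nM, compound 2 `CC1(C)Oc2ccc(C#N)cc2[C@@H](N2CCN(c3ccccc3)C2=O)[C@@H]1O` gives 23700 nM, and compound 3 `CC1(C)Oc2ccc(C#N)cc2[C@@H](/N=C(\NC#N)Nc2cccc(Cl)c2)[C@@H]1O` gives 600 nM, the lowest of the three numbers and thus the strongest inhibitor among them, since its gaps to compound 1 and to compound 2 both lie beyond the scatter. Compound 4 `CC1(C)Oc2ccc(C#N)cc2[C@@H](/N=C(\NC#N)Nc2cccc(C(=O)O)c2)[C@@H]1O` differs from compound 3 in a single place: carboxy in place of chloro on an aromatic carbon. For the measured compounds named here, no measured pair shows this exchange, so the data give no direct guide. A modest weakening of inhibition is nonetheless expected, a 5.0-fold higher number from compound 3 to compound 4 (0.70 log units; beyond the scatter), somewhat beyond the scatter. Compound 4 is therefore estimated at 3000 nM, with a range from 800 nM to 12000 nM.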

Compound 4, half-maximal inhibitory concentration: > 100000 nM
Compound 4 ended at the assay's limit (the forecaster's own chance of this, stated with the estimate: 10%); middle value at least 33-fold (1.52 log units) from the limit.
By their numbers in this assay, from the lowest: compound 3; then compound 1; then compound 2. At a limit, above all of these: compound 4.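

In this assay, the aromatic carbon meta to a large group is far from indifferent to what it carries: carboxy in place of chloro gives an at least 160-fold higher number from compound 3 to compound 4 (2.22 log units; beyond the scatter). Compound 4 stands at a limit of the assay and not at a number: the limit of > 100000 nM in this assay, at which 1 of the 4 values shown sits. The earlier compounds shown here, none a single change from another, gave no view of a change at this carbon alone.

The compounds shown cannot tell whether the loss is specific to carboxy or would also appear with a methyl ester or a primary amide at this carbon. The reason for the loss also stays open.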